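One Chlorine Added to the Phenyl of Compound 2

A few compounds are considered here, and "the series" means these few. Any claim that something is new, unique, unknown or untested is made for them only; others in the source may bear on it.

This small set comprises compound 1 `C#CCOc1ccc2oc(=O)ccc2c1`, for which compound 1 in a functional assay on HL-60 cells (Homo sapiens) for cytotoxicity, read by MTT assay, with a stated time of 48 h (on this read-out lower numbers stand for stronger inhibition and higher numbers for weaker inhibition), shows "not determined" (no result reported), and two compounds that share its core. Compound 2 `O=c1ccc2cc(OCc3cc(-c4ccccc4)no3)ccc2o1` gives 43300 nM in this assay, and compound 3 `O=c1ccc2cc(OCc3cc(-c4ccc5ccccc5c4)no3)ccc2o1` gives 55700 nM. These two numbers lie within the scatter of each other, so the data do not separate them, and compound 2 simply holds the lower of the two figures shown.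

Compound 4 `O=c1ccc2cc(OCc3cc(-c4ccc(Cl)cc4)no3)ccc2o1` differs from compound 2 by a single change: chloro in place of hydrogen on an aromatic carbon. Among the compounds with values here, no measured pair in this set shows such a change, so the expectation rests on the weak effect of the earlier change alone. The expected step of a 1.1-fold lower number from compound 2 to compound 4 (0.06 log units; within the scatter) is therefore small, with no direction beyond the scatter. Compound 4 is estimated at 38000 nM, with a range of 15000 nM to 90000 nM.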

Compound 4, half-maximal inhibitory concentration: 44600 nM
Beside the measured number, compound 4's estimate is 1.2-fold (0.07 log units) below it; low and high end bracket the measured number.
By their numbers in this assay, from the lowest: compounds 2, 4 and 3 (each within the scatter of the next).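

In this assay chloro in place of hydrogen, para to a large group, brings a 1.0-fold higher number from compound 2 to compound 4 (0.01 log units; within the scatter) and gives the first measured view of this change. At this position, in this one cell assay, going from phenyl to 4-chlorophenyl leaves compound 2 and compound 4 unseparated by the data. From the compounds shown here alone, whether an amine, a carboxylic acid or a methoxy group at the same place would move the number beyond the scatter stays open. So does the effect of a longer chain there. No measurement at hand offers an explanation for this result.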